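Adding sec-butyl to compound 2: working notes

A few compounds are considered here, and "the series" means these few. Any claim that something is new, unique, unknown or untested is made for them only; others in the source may bear on it.

Measured in a functional assay on HepG2 cells (Homo sapiens) for antiproliferative activity, read by sulforhodamine B assay, with a stated time of 72 h; on this read-out lower numbers stand for stronger inhibition and higher numbers for weaker inhibition:
- compound 1 `CC[C@H](C)[C@@H](NC(=O)OC(C)(C)C)C(=O)Nc1ccc2ncnc(Nc3cccc(C(F)(F)F)c3)c2c1`: > 50000 nM (a limit)
- compound 2 `CC(C)(C)OC(=O)NCC(=O)Nc1ccc2ncnc(Nc3cccc(Br)c3)c2c1`: 8300 nM

Within the data shown here, compound 2 holds the only actual number in this assay, as the other result is a limit. The next structure, compound 3 `CC[C@H](C)[C@@H](NC(=O)OC(C)(C)C)C(=O)Nc1ccc2ncnc(Nc3cccc(Br)c3)c2c1`, differs from compound 2 by sec-butyl in place of hydrogen on a saturated chain carbon bound to an amide-type nitrogen and a carbonyl carbon, with sec-butyl in place of hydrogen on a saturated chain carbon bound to an amide-type nitrogen and a carbonyl carbon. Among the measured compounds shown here, no measured step bears on this change. Weakening beyond the usual scatter is expected in this assay, since compound 1, which also carries sec-butyl, reaches the limit of > 50000 nM. The expected change is a 2.4-fold higher number from compound 2 to compound 3 (0.38 log units; beyond the scatter). For compound 3 the estimated value is 20000 nM, with an expected range of 7000 nM to 50000 nM.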

Compound 3, half-maximal inhibitory concentration: 34000 nM
Estimate against measurement, compound 3: 1.7-fold (0.23 log units) below; low and high end bracket the measured number.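

In this assay, sec-butyl on the saturated chain carbon bound to an amide-type nitrogen and a carbonyl carbon now has a measured size on the bromo compounds: a 4.1-fold higher number from compound 2 to compound 3 (0.61 log units; beyond the scatter). Compound 3 still gives a real number with sec-butyl in place, whereas compound 1 gave only a limit. Bromo in place of trifluoromethyl on an aromatic carbon gives an at least 1.4-fold lower number from compound 1 to compound 3 (0.16 log units; that floor lies within the scatter), and this comparison stays open-ended: the limit of > 50000 nM in this assay, at which 1 of the 3 values shown sits.

The compounds shown leave open whether a smaller methyl group on this carbon would give a smaller step. They also leave open how a free amine would compare with the carbamate on this chain.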